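Swapping an amide for a phenyltriazole: a stability estimate

The compounds below may be only part of what the source reports. "The series", "measured", "known", "first", "only" and "open" are said of these compounds alone.

Compound 1 `COc1ccc(-c2c(C)sc3c(N4CC[C@@H](NC(C)=O)C4)nc(C)nc23)cc1OC` in an ADME assay on microsomes from liver (Mus musculus) for metabolic stability, read by LC-MS, with NADPH named in the record, with a stated time of 60 min, tested at 1 uM, in the absence of a further agent (on this read-out lower numbers stand for a less stable compound and higher numbers for a more stable compound), gives > 95%, which is a limit of the assay rather than a number.
Compound 2 `CC(=O)N[C@@H]1CCN(c2cc(C)nn3c(-c4ccccc4)c(C)nc23)C1` in this assay gives > 95%, again a limit of the assay.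
Compound 3 `COc1ccc(-c2c(C)nc3c(N4CC[C@@H](NC(=O)C(F)(F)F)C4)cc(C)nn23)cc1OC` in this assay gives > 95%, also a limit of the assay.

All three measured compounds sit at the limit of > 95% in this assay, at which 3 of the 3 values shown sit, so none can be ranked against another, and compound 3 stands at that limit alongside the rest. Compound 4 `COc1ccc(-c2c(C)nc3c(N4CC[C@@H](n5cc(-c6ccccc6)nn5)C4)cc(C)nn23)cc1OC` has not yet been measured. It differs from compound 3 in one place: 4-phenyl-1H-1,2,3-triazol-1-yl in place of ((trifluoromethyl)carbonyl)amino on a saturated ring carbon. Within the data shown here, no measured pair in this set shares a change of this kind, so there is no measured step to lean on. Among the measured compounds shown here, the only guide is that all three compounds reached (the limit of > 95% in this assay, at which 3 of the 3 values shown sit), which leaves room for a decrease in this assay that the assay could resolve. Compound 4 is therefore expected to remain largely intact, with an estimated 70% (range 35% to 95%), which would mean an expected step of a number at least 25 percentage points lower from compound 3 to compound 4 (beyond the scatter).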

Compound 4, percent of the compound remaining: "unstable" (no number reported)
The entry for compound 4 holds no number, and the estimate cannot be compared.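

In this assay, among these compounds, compound 4 is recorded as "unstable" (no number reported), so no step from compound 3 to compound 4 can be read. The compounds shown leave open how much of compound 4 remains, and how compound 1, compound 2 and compound 3, all at the assay limit, rank against one another.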